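Compound 3: dimethylamino in place of hydroxy

The compounds below may be only part of what the source reports. "The series", "measured", "known", "first", "only" and "open" are said of these compounds alone.

Measured in a physicochemical assay for solubility, read by HPLC; on this read-out higher numbers stand for higher solubility and lower numbers for lower solubility:
- compound 1 `Cc1ccc([C@H](C(=O)N(C)C)N2C(=O)[C@@H](C3Cc4ccccc4C3)NC(=O)[C@H]2CC(C)C)cn1` gives > 236 ug/mL (a limit)
- compound 2 `CC(C)C[C@@H]1C(=O)N[C@H](C2Cc3ccccc3C2)C(=O)N1[C@@H](C(=O)N(C)C)c1ccc(O)nc1` gives > 240 ug/mL (a limit)

Compound 2 stands at > 240 ug/mL and this value is a limit. Compound 3 `CC(C)C[C@@H]1C(=O)N[C@H](C2Cc3ccccc3C2)C(=O)N1[C@@H](C(=O)N(C)C)c1ccc(N(C)C)nc1` carries dimethylamino in place of hydroxy on an aromatic carbon. Among the measured compounds shown here, the only measured step at this carbon is a step that the two limits leave unreadable from compound 1 to compound 2 and it gives no size to carry over. Compound 1, with methyl on that carbon, gives > 236 ug/mL and this too is a limit. On that value a large fall is not expected. In this assay a small fall or none is expected, an estimated at least 1.2-fold lower number from compound 2 to compound 3 (0.07 log units; that floor lies within the scatter). For compound 3 the estimate is 200 ug/mL, with an expected range of 80 ug/mL to 320 ug/mL.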

Compound 3, solubility: 233 ug/mL
Beside the measured number, compound 3's estimate is 1.2-fold (0.07 log units) below it; low and high end bracket the measured number.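

Among the compounds shown here, at this aromatic carbon, next to the ring nitrogen, compound 3 gives the first reading in this assay that is a number and not a limit. Dimethylamino in place of hydroxy reads as an at least 1.0-fold lower number from compound 2 to compound 3 (0.01 log units; that floor lies within the scatter), and dimethylamino in place of methyl reads as an at least 1.0-fold lower number from compound 1 to compound 3 (0.00 log units; that floor lies within the scatter). Each of these steps is therefore a floor that does not reach beyond the scatter, so the shown values separate none of the three groups at this carbon.

On these data alone, the values of compound 1 and compound 2 are limits, so the true size of both steps stays open. Also open, as far as these compounds go, is how a carboxylic acid, a methoxy group or an amine with a longer chain at this carbon would read against compound 3.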